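A few compounds are considered here, and "the series" means these few. Any claim that something is new, unique, unknown or untested is made for them only; others in the source may bear on it.

Compounds with numbers in hand:
compound 1 `O=C(/C(=C\c1ccc(Br)cc1)SCc1ccc(Cl)cc1)c1ccc(Cl)cc1`, 1000 nM;
compound 2 `Cc1ccc(/C=C(/Sc2ccc(F)cc2)C(=O)c2ccc(Cl)cc2)s1`, 25000 nM;
compound 3 `O=C(/C(=C\c1ccc(O)c([N+](=O)[O-])c1)S(=O)(=O)Cc1ccc(Br)cc1)c1ccc(Br)cc1`, 10000 nM.

In a functional assay on DU-145 cells (Homo sapiens) for inhibition, read by trypan blue exclusion, with a stated time of 96 h (a higher number here means a weaker inhibitor of growth, a lower number a stronger inhibitor of growth), compound 2 stands at the highest of the three numbers, with compound 3 nearest and compound 1 furthest, both gaps beyond the scatter. Compound 4 `Cc1ccc(/C=C(/SCc2ccc(Cl)cc2)C(=O)c2ccc(Cl)cc2)s1` is not yet measured. It differs from compound 2 in one place: 4-chlorobenzyl in place of 4-fluorophenyl on a sulfur. Within the data shown here, no measured pair shows this change on its own, so its size is uncertain; still a step downward beyond the scatter seems likely, because compound 1 also carries 4-chlorobenzyl on its sulfur and gives 1000 nM in this assay. The step expected from compound 2 to compound 4 is estimated at a 6.3-fold lower number from compound 2 to compound 4 (0.80 log units; beyond the scatter). Compound 4 is therefore expected to give about 4000 nM, within 800 nM to 20000 nM.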

Compound 4, concentration for 50% growth inhibition: 50000 nM
Estimate against measurement, compound 4: 13-fold (1.10 log units) below, and the stated range ends below it.
By their numbers in this assay, from the lowest: compound 1; then compound 3; then compounds 2 and 4 (each within the scatter of the next).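

In this assay, 4-chlorobenzyl in place of 4-fluorophenyl on a sulfur gives a 2.0-fold higher number from compound 2 to compound 4 (0.30 log units; within the scatter), so 4-chlorobenzyl on this sulfur does not by itself bring the low number of compound 1. The large step lies at the other place: 5-methylthiophen-2-yl in place of 4-bromophenyl on a double-bonded chain carbon gives a 50-fold higher number from compound 1 to compound 4 (1.70 log units; beyond the scatter). No measurement shown here explains either step.

Open, on these data alone, is whether a plain phenyl or a pyridine on that carbon would give a number like that of compound 1 or compound 4. Also open, as far as these compounds go, is whether 4-bromophenyl would keep its advantage with 4-fluorophenyl on the sulfur.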